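The compounds below may be only part of what the source reports. "The series", "measured", "known", "first", "only" and "open" are said of these compounds alone.

Among the measured compounds shown here, compound 1 `CC(=O)C1=C(C)NC(=O)NC1c1ccoc1` gives 6% in an assay on membranes from CHO cells for displacement of a labelled ligand from adenosine receptor A1 (Homo sapiens), read by scintillation counting, with a stated time of 60 min, tested at 1 uM (on this read-out higher numbers stand for more inhibition at the one concentration tested (going by the name of the read-out) and lower numbers for less inhibition), and compound 2 `CC1=C(C(=O)SC(C)C)C(c2ccoc2)NC(=O)N1` gives 9%; the only single-place step among the measured compounds, a number 3 percentage points higher from compound 1 to compound 2 (within the scatter), alters a group on a carbonyl carbon and leaves the ring on the saturated ring carbon untouched. Compound 3 `CC1=C(C(=O)OCC2CCC2)C(c2ccco2)NC(=O)N1` gives 42%, the highest of the three numbers, beyond the scatter from both others. Compound 4 `CC1=C(C(=O)OCC2CCC2)C(c2ccoc2)NC(=O)N1` differs from compound 3 by furan-3-yl in place of furan-2-yl on a saturated ring carbon. For the measured compounds named here, no measured step moves this ring alone, and compounds 1 and 2, which carry furan-3-yl, differ from compound 3 in other places too, so their numbers give no clean guide. The step of a number 7 percentage points lower from compound 3 to compound 4 (within the scatter) is expected to stay within the scatter. Compound 4 is expected to give 35%, in a range from 15% to 55%.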

Compound 4, a percentage reported as inhibition, at one concentration (the size of the read-out at that concentration, not a potency): 46%
For compound 4 the middle estimate is 11 percentage points below the measured one, and the stated range covers the measured number.
By their numbers in this assay, from the lowest: compounds 1 and 2 (each within the scatter of the next); then compounds 3 and 4 (each within the scatter of the next).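

In this assay, furan-3-yl in place of furan-2-yl on the saturated ring carbon gives a number 4 percentage points higher from compound 3 to compound 4 (within the scatter) and so leaves the two furan attachments unseparated. The group on the carbonyl carbon weighs far more: cyclobutylmethoxy gives a number 37 percentage points higher from compound 2 to compound 4 (beyond the scatter) when it replaces isopropylsulfanyl, and a number 40 percentage points higher from compound 1 to compound 4 (beyond the scatter) when it replaces methyl. Nothing at hand explains these steps. As far as these compounds go, what a phenyl ring would do on the saturated ring carbon stays open, as does the effect of a longer chain such as hexyloxy on the carbonyl carbon.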